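Phenyl to Pyridin-2-yl on a Benzyloxy Side Chain

The source may hold more compounds than are shown below. What is called first, only, known or untested is meant among the compounds shown, and "the series" means these compounds.

Compound 3 `O=C(O)CCn1c(=O)oc2cc(OCc3ccccc3)c(Cl)cc21` carries a benzyloxy group on the shared core. In a physicochemical assay for permeability, using PAMPA (a higher number here means that the compound crosses the layer faster, a lower number that the compound crosses the layer more slowly), compound 3 gives "not determined" (no result reported), so no number places it among the others. Compound 1 `C[C@@H](Oc1cc2oc(=O)n(CCC(=O)O)c2cc1Cl)c1ccc(F)cn1` gives 31 nm/s in this assay. Compound 2 `CCc1cc2oc(=O)n(CCC(=O)O)c2cc1Cl` gives < 10 nm/s in this assay, which is a limit and not a number, namely (the limit of < 10 nm/s in this assay, at which 1 of the 3 values shown sits). Compound 4 `O=C(O)CCn1c(=O)oc2cc(OCc3ccccn3)c(Cl)cc21` differs from compound 3 by pyridin-2-yl in place of phenyl on a saturated chain carbon bound to an oxygen on an aromatic ring. Within the data shown here, with no measured step of this kind among the three, the change from compound 3 to compound 4 is expected to move this assay by little, a small fall at most, within the scatter. Compound 1, with its own pyridine ether, gives 31 nm/s as the nearest guide. Compound 4 is expected to give about 25 nm/s, ranging from 10 nm/s to 60 nm/s.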

Compound 4, apparent permeability: 11 nm/s
Estimate against measurement, compound 4: 2.3-fold (0.36 log units) above; the measured number falls inside the stated range.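

With (pyridin-2-yl)methoxy in place of ethyl on an aromatic carbon, this assay shows an at least 1.1-fold higher number from compound 2 to compound 4 (0.04 log units; that floor lies within the scatter), so no rise beyond the scatter can be claimed. Compound 2 gives < 10 nm/s, which is a limit of the assay and not a number: the limit of < 10 nm/s in this assay, at which 1 of the 4 values shown sits. Compound 3 has no number, so the step from phenyl to pyridin-2-yl itself cannot be read. Still open, as far as these compounds go, is how this assay would respond to an amine on the pyridin-2-yl ring, or to a longer chain in place of the (pyridin-2-yl)methoxy group.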